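From a branched group to benzyl in a cell toxicity test

This account rests on a few compounds, and the source may have more. Where it says the series, first, only, none or still open, it means among the compounds named here.

- Compound 1 (`CC(C)C(Nc1nc(Cl)nc2c1ncn2[C@H]1[C@H](O)[C@H](O)[C@]2(CO)C[C@H]12)C(C)C`): > 100000 nM (a limit)
- Compound 2 (`NCCCNC(=O)[C@@]12C[C@@H]1[C@@H](n1cnc3c(NC(C4CC4)C4CC4)nc(Cl)nc31)[C@H](O)[C@@H]2O`): 50000 nM
- Compound 3 (`CC(C)(O)[C@@H](Nc1nc(Cl)nc2c1ccn2[C@H]1[C@H](O)[C@H](O)[C@]2(CO)C[C@H]12)C1CC1`): 63000 nM

In an ADME assay on Vero 76 cells (Chlorocebus sabaeus) for cytotoxicity, read by neutral red uptake (a higher number here means that more compound is tolerated, a lower number that less compound is tolerated), compound 1 gives only a limit (> 100000 nM) and not a number.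

Compound 4 (`OC[C@@]12C[C@@H]1[C@@H](n1cnc3c(NCc4ccccc4)nc(Cl)nc31)[C@H](O)[C@@H]2O`) keeps the core of compound 1 but changes one group: benzyl in place of 1-isopropyl-2-methylpropyl on a nitrogen on an aromatic ring. This puts benzyl in place of 1-isopropyl-2-methylpropyl on a nitrogen on an aromatic ring.

For the measured compounds named here, no measured pair isolates this change, so the guide is compound 2 (50000 nM) and compound 3 (63000 nM), which both gave numbers. A small expected move toward less compound tolerated is the forecast (an at least 1.3-fold lower number from compound 1 to compound 4 (0.12 log units; that floor lies within the scatter)). For compound 4 the estimate is 75000 nM (expected range 30000 nM to 100000 nM).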

Compound 4, half-maximal cytotoxic concentration: > 100000 nM
Compound 4 ended at the assay's limit; the forecaster's own chance of this, stated with the estimate: 45%; middle value at least 1.3-fold (0.12 log units) from the limit.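

In this assay compound 1 and compound 4 both stop at a limit rather than a number, so no step between them can be read: the limit of > 100000 nM in this assay, at which 2 of the 4 values shown sit.

From the compounds shown here alone, whether benzyl or 1-isopropyl-2-methylpropyl on this nitrogen is better tolerated remains open.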